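Swapping the benzamide para substituent in a bile acid receptor agonist series

A few compounds are considered here, and "the series" means these few. Any claim that something is new, unique, unknown or untested is made for them only; others in the source may bear on it.

Compound 1 `CC(C)(C)c1ccc(C(=O)NCc2ccc(N)cc2Cl)cc1` gives 40 nM in an assay on HeLa cells for agonist activity at Bile acid receptor (Homo sapiens), read by a luciferase reporter, with a stated time of 24 h; a lower number here means that less compound is needed, a higher number that more compound is needed for the effect. Compound 2 `CC(C)S(=O)(=O)Nc1ccc(CNC(=O)c2ccc(C(C)(C)C)cc2)c(Cl)c1` gives 420 nM. Compound 3 `CN(C)c1ccc(C(=O)NCc2ccc(NS(C)(=O)=O)cc2Cl)cc1` gives 1460 nM.

Compound 3 stands highest of the three numbers in this assay; its nearest neighbour is compound 2, and compound 1 is furthest away. Among the measured compounds shown here, the only single-site step among the measured compounds, an 11-fold higher number from compound 1 to compound 2 (1.02 log units; beyond the scatter), concerns the nitrogen on the aromatic ring, not the place changed here. Compound 4 `CC(C)(O)c1ccc(C(=O)NCc2ccc(NS(C)(=O)=O)cc2Cl)cc1` differs from compound 3 by 1-hydroxy-1-methylethyl in place of dimethylamino on an aromatic carbon. For the measured compounds named here, compounds 1 and 2, which carry tert-butyl at that place, give the two lower numbers, but they also differ at the sulfonyl, so no measured step bears directly on this change. A modest step is expected, a 2.1-fold lower number from compound 3 to compound 4 (0.32 log units; beyond the scatter), giving an estimate for compound 4 of 700 nM, from 200 nM to 2500 nM.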

Compound 4, half-maximal effective concentration: 32 nM
For compound 4 the middle estimate is 22-fold (1.34 log units) above the measured one, and the stated range ends above it.
By their numbers in this assay, from the lowest: compounds 4 and 1 (each within the scatter of the next); then compound 2; then compound 3.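

Among the compounds shown here, at this place, para to a large group, the earlier compounds offered no single-place step; now there is one, and it is large: in this assay, 1-hydroxy-1-methylethyl in place of dimethylamino gives a 46-fold lower number from compound 3 to compound 4 (1.66 log units; beyond the scatter) on an otherwise unchanged core. The swap adds a hydrogen-bond donor, but no measurement shown explains the step.

On these data alone, how a carboxylic acid or a methoxy group would behave at this place remains open. So does whether the same swap would give a similar step with the other nitrogen substituents of compounds 1 and 2.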